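This account rests on a few compounds, and the source may have more. Where it says the series, first, only, none or still open, it means among the compounds named here.

The measured compounds:
compound 1 `CC[C@H](C)[C@H]1C(=O)N[C@H](Cc2ccc(O)c(Br)c2)C(=O)N[C@@H](C(C)(C)O)C(=O)O[C@H](c2ccccc2)[C@H](C)/C=C/C=C(\C)[C@H](OC)C/C=C(\C)C(=O)N1C`, 11.4 nM in a functional assay on PANC-1 cells (Homo sapiens) for antiproliferative activity; on this read-out higher numbers stand for weaker inhibition and lower numbers for stronger inhibition
compound 2 `CC[C@H](C)[C@H]1C(=O)N[C@H](Cc2cc(Cl)c(O)c(Cl)c2)C(=O)N[C@@H](C(C)C)C(=O)O[C@H](c2ccccc2)[C@H](C)/C=C/C=C(\C)[C@H](OC)C[C@@H]2O[C@@]2(C)C(=O)N1C`, 15.5 nM in this assay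
compound 3 `CC[C@H](C)[C@H]1C(=O)N[C@H](Cc2cc(Cl)c(O)c(Cl)c2)C(=O)N[C@@H](C(C)(C)O)C(=O)O[C@H](c2ccccc2)[C@H](C)/C=C/C=C(\C)[C@H](OC)C[C@@H]2O[C@@]2(C)C(=O)N1C`, 12.2 nM in this assay

Compound 3 sits second highest of the three numbers, but all three lie within the scatter of one another: compound 1 is a touch lower and compound 2 a touch higher, neither difference counting as real. Within the data shown here, the only single-point step among them is a 1.3-fold lower number from compound 2 to compound 3 (0.10 log units; within the scatter), which also stays within the scatter.

Compound 4 `CC[C@H](C)[C@H]1C(=O)N[C@H](Cc2ccc(O)c(Br)c2)C(=O)N[C@@H](C(C)(C)O)C(=O)O[C@H](c2ccccc2)[C@H](C)/C=C/C=C(\C)[C@H](OC)C[C@@H]2O[C@@]2(C)C(=O)N1C` is built from compound 3 by 3-bromo-4-hydroxyphenyl in place of 3,5-dichloro-4-hydroxyphenyl on a saturated chain carbon bound to a saturated ring carbon. Among the measured compounds shown here, no measured step bears directly on this change, since no pair among the measured compounds differs only there. The closest guidance is compound 1, which carries the same 3-bromo-4-hydroxyphenyl group on the same saturated chain carbon bound to a saturated ring carbon and gives 11.4 nM in this assay. Because compound 1 gives 11.4 nM and compound 3 gives 12.2 nM, compound 4 is expected to show a 1.1-fold lower number from compound 3 to compound 4 (0.04 log units; within the scatter), a step of no size beyond the scatter. Compound 4 is therefore estimated at 11 nM in this assay, with a plausible range from 5 nM to 25 nM.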

Compound 4, half-maximal inhibitory concentration: 9.61 nM
Beside the measured number, compound 4's estimate is 1.1-fold (0.06 log units) above it; measured number inside the range.
By their numbers in this assay, from the lowest: compounds 4, 1, 3 and 2 (each within the scatter of the next).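

In this assay, among these compounds, the exchange of 3,5-dichloro-4-hydroxyphenyl for 3-bromo-4-hydroxyphenyl gives the first direct reading at this place, on a saturated chain carbon bound to a saturated ring carbon: a 1.3-fold lower number from compound 3 to compound 4 (0.10 log units; within the scatter). With the rest of the molecule held the same, the two groups cannot be told apart on this read-out, even though the change removes two chlorine atoms and brings in one bromine atom. Nothing available explains why the two groups read alike.

The compounds shown leave open whether any halogen is needed here at all, as every compound carries one on the 4-hydroxyphenyl group, and a plain 4-hydroxyphenyl or a 4-methoxyphenyl group is not among them. They also leave open whether a larger change at this place, such as a 4-aminophenyl group or a longer chain between the aromatic ring and the shared core, would move the number beyond the scatter, and whether the two halogenated groups would also read alike on any other read-out.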